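Replacing hydroxy with amino on the amide-type nitrogen

The source may hold more compounds than are shown below. What is called first, only, known or untested is meant among the compounds shown, and "the series" means these compounds.

Compound 1 `Nc1ccccc1NC(=O)c1ccc(NCc2nc(-c3ccccc3)nn2-c2ccccc2)cc1`: in an assay on Sf9 cells for inhibition of protein deacetylase HDAC6 (Homo sapiens), read by fluorescence, with a stated time of 40 min, tested at 100 nM (on this read-out lower numbers stand for less inhibition and higher numbers for more inhibition at the one concentration tested (going by the name of the read-out)), compound 1 gives 5%.
Compound 2 `NC(=O)c1ccc(NCc2nc(-c3ccccc3)nn2-c2ccccc2)cc1`: compound 2 gives -4.4%.
Compound 3 `O=C(NO)c1ccc(NCc2nc(-c3ccccc3)nn2-c2ccccc2)cc1`: compound 3 gives 72.6%.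

Compound 3 stands highest of the three numbers; its nearest neighbour is compound 1, as a number 67.6 percentage points higher from compound 1 to compound 3 (beyond the scatter) shows, and compound 2 lies furthest, as a number 77 percentage points higher from compound 2 to compound 3 (beyond the scatter) shows. Compound 4 `NNC(=O)c1ccc(NCc2nc(-c3ccccc3)nn2-c2ccccc2)cc1` differs from compound 3 in one place: amino in place of hydroxy on an amide-type nitrogen. Both large steps bear on this change, since each of them introduced the hydroxy that compound 4 now loses; compounds 1 and 2, which lack it, sit within the scatter of each other. Within the data shown here, the amino group itself has no measured counterpart here. A fall beyond the scatter in this assay is therefore expected for compound 4, though not necessarily all the way back to compound 2. Compound 4 is expected to give about 15%, between -5% and 45%, a step of a number 57.6 percentage points lower from compound 3 to compound 4 (beyond the scatter).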

Compound 4, a percentage reported as inhibition, at one concentration (the size of the read-out at that concentration, not a potency): 10%
Estimate against measurement, compound 4: 5 percentage points above, within the range that was stated.
By their numbers in this assay, from the lowest: compounds 2, 1 and 4 (each within the scatter of the next, the first and the last beyond it); then compound 3.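

In this assay, amino does not stand in for hydroxy on the amide-type nitrogen: a number 62.6 percentage points lower from compound 3 to compound 4 (beyond the scatter) is the price of the exchange, even though the computed counts of heavy atoms, donors and acceptors match for the two groups. Against the hydrogen, amino still brings a modest rise, with a number 14.4 percentage points higher from compound 2 to compound 4 (beyond the scatter) as the measure, while a number 5 percentage points higher from compound 1 to compound 4 (within the scatter) leaves it level with 2-aminophenyl. Nothing available explains these differences. Still open, on these data alone, is whether a methoxy or methylamino group on this nitrogen would follow hydroxy or amino, and how a carboxylic acid in place of hydroxycarbamoyl would read.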